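Replacing a Phenylethenyl Arm with a Chlorofuran Ring

A few compounds are considered here, and "the series" means these few. Any claim that something is new, unique, unknown or untested is made for them only; others in the source may bear on it.

Of the compounds shown here, three built on one shared core have been measured in a functional assay on NCI-H1299 cells (Homo sapiens) for cytotoxicity, read by MTT assay, with a stated time of 48 h; on this read-out lower numbers stand for stronger inhibition and higher numbers for weaker inhibition. Compound 1 `C=C(C)Cn1cc(CO[C@H]2CC(=O)[C@@H]3OC[C@H]2O3)nn1` gives 14300 nM. For the measured compounds named here, compound 2 `O=C1C[C@H](OCc2cn(C3CCCCC3)nn2)[C@H]2CO[C@@H]1O2` gives 12000 nM; the only single-point step among the measured compounds, a 1.2-fold lower number from compound 1 to compound 2 (0.08 log units; within the scatter), swaps a group on an aromatic nitrogen. Compound 3 `O=C1C[C@H](OCc2cc(/C=C/c3ccccc3)no2)[C@H]2CO[C@@H]1O2` gives 7100 nM, the lowest of the three numbers, yet its gaps to compound 2 and to compound 1 both lie within the scatter, so the three cannot be ranked with confidence.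

Compound 4 `O=C1C[C@H](OCc2cc(-c3ccc(Cl)o3)no2)[C@H]2CO[C@@H]1O2` differs from compound 3 in one place: 5-chlorofuran-2-yl in place of 2-phenylethenyl on an aromatic carbon. Going by the values given here, no measured step bears on this position. Among the compounds with values here, the step from compound 1 to compound 2 concerns a different part of the structure and was itself within the scatter, and nothing among the measured compounds shows how much the group at this place changes the read-out. With no evidence pointing either way, the expectation is that compound 4 stays close to compound 3, and the step of a 1.0-fold lower number from compound 3 to compound 4 (0.01 log units; within the scatter) is estimated to remain within the scatter. Compound 4 is therefore estimated at 7000 nM in this assay, with a range from 2500 nM to 20000 nM.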

Compound 4, half-maximal inhibitory concentration: 7600 nM
Compound 4: middle estimate off by 1.1-fold (0.04 log units), on the low side; low and high end bracket the measured number.
By their numbers in this assay, from the lowest: compounds 3, 4, 2 and 1 (each within the scatter of the next).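

The swap at this aromatic carbon is a large one on paper: 2-phenylethenyl, with its six-membered aromatic ring of carbon only and a double bond outside that ring, gives way to 5-chlorofuran-2-yl, a five-membered aromatic ring holding one oxygen and bearing a chlorine. Even so, this assay shows only a 1.1-fold higher number from compound 3 to compound 4 (0.03 log units; within the scatter), so this position carries either group with no readable change in the number, which the earlier compounds could not show because none of their steps touched this place. No measurement available here accounts for the two groups reading alike.

As far as these compounds go, both groups carry an aromatic ring, so it remains open whether something quite different at this place, such as a methyl group, an amine or a carboxylic acid, would move the number beyond the scatter. Also open, from the compounds shown here alone, is what the chlorine itself contributes, a question that a plain furan-2-yl group at the same place could answer.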